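A few compounds are considered here, and "the series" means these few. Any claim that something is new, unique, unknown or untested is made for them only; others in the source may bear on it.

Measured compounds:
- compound 1, `O=C(Nc1ccc2nc(Nc3ccc(Cl)c(Cl)c3)c(Nc3ccc(Cl)c(Cl)c3)nc2c1)c1cccc(C(F)(F)F)c1`: "nd" (no result reported) in a toxicity assay on HepG2 cells (Homo sapiens) for cytotoxicity, read by MTT assay, with a stated time of 72 h; a higher number here means that more compound is tolerated, a lower number that less compound is tolerated
- compound 2, `CC(=O)Nc1ccc2nc(Nc3ccc(Cl)c(Cl)c3)c(Nc3ccc(Cl)c(Cl)c3)nc2c1`: 4590 nM

Within the data shown here, compound 2 holds the only number in this assay; compound 1 gives no result there, so compound 2 stands alone and no rank among measured compounds can be stated. Compound 3, `O=C(Nc1ccc2nc(Nc3ccc(Cl)c(Cl)c3)c(Nc3ccc(Cl)c(Cl)c3)nc2c1)c1ccco1`, carries furan-2-yl in place of methyl on a carbonyl carbon; cut one bond further out, the difference reads acetyl to (furan-2-yl)carbonyl. Among the measured compounds shown here, no step between two measured compounds exists for comparison. In this assay a step toward less tolerated compound is expected, of about a 1.5-fold lower number from compound 2 to compound 3 (0.18 log units; within the scatter), a size not far beyond the scatter. For compound 3 a value of 3000 nM is estimated, within 1000 nM to 9000 nM.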

Compound 3, half-maximal cytotoxic concentration: 5690 nM
The estimate for compound 3 lay 1.9-fold (0.28 log units) below the measured number, and the stated range covers the measured number.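

In this assay, among these compounds, the exchange of methyl for furan-2-yl on a carbonyl carbon gives a 1.2-fold higher number from compound 2 to compound 3 (0.09 log units; within the scatter) and is the only step readable at this position. Compound 2 and compound 3 thus stand within the scatter of each other, although the entering group brings a five-membered aromatic ring and a hydrogen-bond acceptor. No measured evidence bears on this result.

Steps to compound 1 cannot be read, as it gives no result. Open, on these data alone, is how an amine, a carboxylic acid or a longer alkyl chain on this carbonyl carbon would read in this assay here.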